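Adding a Methoxy Group to the Phenyl of Compound 2

This account rests on a few compounds, and the source may have more. Where it says the series, first, only, none or still open, it means among the compounds named here.

In a functional assay on CCRF-CEM cells (Homo sapiens) for antiproliferative activity, read by MTT assay, with a stated time of 48 h, tested at 25 uM (on this read-out lower numbers stand for a stronger effect and higher numbers for a weaker effect at the one concentration tested), compound 2 `OC(CCn1nc2c(Br)c(Br)c(Br)c(Br)c2n1)c1ccccc1` gives 84%, the highest of the three numbers measured. Compound 3 `OC(CCn1nc2c(Br)c(Br)c(Br)c(Br)c2n1)c1ccc(Cl)cc1` gives 69%, and compound 1 `OCC(O)Cn1nc2c(Br)c(Br)c(Br)c(Br)c2n1` gives 56%; both lie beyond the scatter below compound 2. Compound 4 `COc1cccc(C(O)CCn2nc3c(Br)c(Br)c(Br)c(Br)c3n2)c1` has not yet been measured in this assay. It differs from compound 2 by methoxy in place of hydrogen on an aromatic carbon. For the measured compounds named here, the only measured step of a similar kind, a group entering the phenyl ring, is a number 15 percentage points lower from compound 2 to compound 3 (beyond the scatter), with chloro rather than methoxy entering. A modest move in the same direction is therefore expected, with the caveat that the entering group differs. The step expected is a number 10 percentage points lower from compound 2 to compound 4 (within the scatter). For compound 4 the estimate is 74%, within a range of 58% to 90%.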

Compound 4, a percentage reported as activity, at one concentration (the size of the read-out at that concentration, not a potency): 50%
For compound 4 the middle estimate is 24 percentage points above the measured one; the measured number lies below the stated range.
By their numbers in this assay, from the lowest: compounds 4 and 1 (each within the scatter of the next); then compound 3; then compound 2.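

In this assay, the phenyl ring of compound 2 tolerates more than a modest change: methoxy on an aromatic carbon, meta to a large group, gives a large step, a number 34 percentage points lower from compound 2 to compound 4 (beyond the scatter). The 3-methoxyphenyl group also goes further than the 4-chlorophenyl group, a number 19 percentage points lower from compound 3 to compound 4 (beyond the scatter), although the group and its place on the ring both differ in that step. No measurement at hand explains why this step is so large. The effects of the group and its place therefore remain unseparated, and a 4-methoxyphenyl or 3-chlorophenyl group could separate them. Going by these compounds, how an amine at this place would compare also stays open.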